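This account rests on a few compounds, and the source may have more. Where it says the series, first, only, none or still open, it means among the compounds named here.

Compound 1 `COc1cc(/C=N/NC(=O)c2ccncc2)cc(OC)c1O` gives 65% in a functional assay on cells (Mus musculus) for cytotoxicity, read by MTT assay, with a stated time of 24 h, tested at 10 uM (a lower number here means a weaker effect, a higher number a stronger effect of the compound at the concentration tested), the second highest of the three numbers in hand. Compound 2 `COc1cc(/C=N/NC(=O)OCc2ccccc2)cc(OC)c1O` gives 69%, and the change a number 4 percentage points higher from compound 1 to compound 2 (within the scatter) is within the scatter. Compound 3 `COc1cc(/C=N/NC(=O)c2ccncc2)cc(OC)c1OC` gives 4%, a large fall, a number 61 percentage points lower from compound 1 to compound 3 (beyond the scatter). Compound 4 `COc1cc(/C=N/NC(=O)c2ccncc2)cc(O)c1O` differs from compound 1 by hydrogen in place of methyl on an oxygen on an aromatic ring. Going by the values given here, the one step that bears on this is the step from compound 1 to compound 3, which runs the opposite way at a neighbouring oxygen and was large. Because compound 3 gave 4% after the phenol was capped, freeing a second oxygen is expected to keep or slightly strengthen the effect, a number 3 percentage points higher from compound 1 to compound 4 (within the scatter). For compound 4 the estimate is 68%, between 45% and 85%.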

Compound 4, a percentage reported as activity, at one concentration (the size of the read-out at that concentration, not a potency): 80%
Compound 4: the middle estimate sits 12 percentage points below what was measured; low and high end bracket the measured number.
By their numbers in this assay, from the lowest: compound 3; then compounds 1 and 2 (each within the scatter of the next); then compound 4.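

In this assay the change from methoxy to hydroxy gives a number 15 percentage points higher from compound 1 to compound 4 (beyond the scatter) and so shows that a methyl can leave this oxygen with a real gain, not merely without loss. Read with a number 61 percentage points lower from compound 1 to compound 3 (beyond the scatter), the two changes run the same way among compounds 3, 1 and 4: the fewer methyl groups on these oxygens, the higher the number. Nothing available explains this rise. As far as these compounds go, whether an amine or a fluorine at this place would match the hydroxy remains open. So does whether the same change would raise the number on the benzyloxy compound 2.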